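From a thiophene arm to a bare phenyl ring

The compounds below may be only part of what the source reports. "The series", "measured", "known", "first", "only" and "open" are said of these compounds alone.

Of the compounds shown here, three built on one shared core have been tested in a functional assay on the whole organism with Rattus norvegicus as the target, at a dose of 40 mg/kg by the intraperitoneal route; on this read-out lower numbers stand for less inhibition and higher numbers for more inhibition at the one dose given (going by the name of the read-out). Compound 1 `Cc1nc2c(OCc3ccc(C(F)(F)F)cc3)cccn2c1N` gives 78%. Compound 2 `Cc1nc2c(OCc3ccccn3)cccn2c1N` gives 16%. Compound 3 `Cc1nc2c(OCc3cccs3)cccn2c1N` gives 70%. Among these three numbers compound 3 stands second highest: its gap to compound 1 lies within the scatter, whereas the move from compound 2 to compound 3 is a number 54 percentage points higher from compound 2 to compound 3 (beyond the scatter), well beyond the scatter.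

Compound 4 `Cc1nc2c(Oc3ccccc3)cccn2c1N` has not yet been measured. It differs from compound 3 in one place: phenyl in place of (thiophen-2-yl)methyl on an oxygen on an aromatic ring. Within the data shown here, the only measured step, from compound 2 to compound 3, swapped one ring for another while keeping the same chain carbon; here both the ring and the chain carbon change, so that step bears only loosely on the present one. Among the measured compounds shown here, no measured pair shows what removing the chain carbon does. With so little to go on, the expected step in this assay is a number 20 percentage points lower from compound 3 to compound 4 (beyond the scatter), a modest fall carrying wide uncertainty. The estimate for compound 4 is 50%, within a range from 15% to 85%.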

Compound 4, a percentage reported as inhibition, in the whole organism at one dose (the size of the read-out at that dose, not a potency): 34%
Estimate against measurement, compound 4: 16 percentage points above, and the stated range covers the measured number.
By their numbers in this assay, from the lowest: compound 2; then compound 4; then compounds 3 and 1 (each within the scatter of the next).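

In this assay the group on the oxygen cannot be swapped freely: phenyl in place of (thiophen-2-yl)methyl gives a number 36 percentage points lower from compound 3 to compound 4 (beyond the scatter) at this position. The earlier step changed only the ring and kept the chain carbon, whereas this one also removes that carbon, and the read-out responds strongly, though ring and chain carbon change together here and the fall cannot be assigned to either alone. Nothing measured on these compounds gives a reason for the fall.

Going by these compounds, a plain benzyl group on the oxygen would separate the two changes, and whether it would stay close to compound 3 or drop towards compound 4 remains open. A longer chain, such as 2-phenylethyl, leaves open how far from the oxygen the ring can sit.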